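This account rests on a few compounds, and the source may have more. Where it says the series, first, only, none or still open, it means among the compounds named here.

Compound 1 `O=C(O)CC1CCCC1Cc1ccc(OCc2ccc3ccccc3n2)cc1` stands at the top of the three numbers in an assay on membranes from lung (Cavia porcellus) for binding affinity to cysteinyl leukotriene receptor (Homo sapiens) (a higher number here means a weaker inhibitor, a lower number a stronger inhibitor), where compound 1 gives 100 nM. Compound 2 `O=C(O)CCCCc1cccc(OCc2ccc3ccccc3n2)c1` sits level with it, giving 100 nM, a difference within the scatter. Compound 3 `c1ccc2nc(COc3ccc(CC4CCCC4Cc4nnn[nH]4)cc3)ccc2c1` gives 15 nM. Going by the values given here, the single measured step is a 6.7-fold lower number from compound 1 to compound 3 (0.82 log units; beyond the scatter), which alters a different group and does not bear on the present change. Compound 4 `O=C(O)CCCCc1ccc(OCc2ccc3ccccc3n2)cc1` differs from compound 1 by 3-carboxypropyl in place of 2-(carboxymethyl)cyclopentyl on a saturated chain carbon bound to an aromatic carbon. Among the compounds with values here, no measured step covers this change directly. Compound 2 carries the same 3-carboxypropyl chain and returns a number level with compound 1, so no step beyond the scatter is expected. Compound 4 is therefore estimated at 100 nM, with a range from 40 nM to 250 nM. The expected step is no change at the digits printed from compound 1 to compound 4 (within the scatter).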

Compound 4, inhibition constant: 110 nM
For compound 4 the middle estimate is 1.1-fold (0.04 log units) below the measured one; measured number inside the range.
By their numbers in this assay, from the lowest: compound 3; then compounds 1, 2 and 4 (each within the scatter of the next).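

In this assay, 3-carboxypropyl in place of 2-(carboxymethyl)cyclopentyl gives a 1.1-fold higher number from compound 1 to compound 4 (0.04 log units; within the scatter). Going by these compounds alone, on this saturated chain carbon bound to an aromatic carbon, the first direct comparison of the two groups therefore shows that the five-membered non-aromatic ring of carbon only can be absent without a step beyond the scatter. Nothing available explains this result.

Still open, going by these compounds, is whether 1H-tetrazol-5-yl in place of carboxy on the 3-carboxypropyl chain of compound 4 would repeat a 6.7-fold lower number from compound 1 to compound 3 (0.82 log units; beyond the scatter). On these data alone, the effect of a longer chain bearing the carboxylic acid also remains open.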